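Dimethylsulfamoyl Chain Variant of a Sulfonyl Hydrazide Lead

The source may report more compounds than this note shows. Statements on the series, on what has been measured and on what is new or still open speak of the compounds shown alone.

Compound 3 `NNS(=O)(=O)CCNc1nonc1/C(=N/O)Nc1ccc(F)c(Br)c1` gives 135 nM in an assay on isolated protein for inhibition of Indoleamine 2,3-dioxygenase 1 (Homo sapiens), read by fluorescence, with a stated time of 60 min (a higher number here means a weaker inhibitor, a lower number a stronger inhibitor), the lowest of the three numbers measured. Compound 1 `[O-][S+]1CC(Nc2nonc2/C(=N/O)Nc2ccc(F)c(Br)c2)C1` gives 212 nM in this assay, and the step of a 1.6-fold lower number from compound 1 to compound 3 (0.20 log units; within the scatter) lies within the scatter. Compound 2 `O=S(=O)(CCNc1nonc1/C(=N/O)Nc1ccc(F)c(Br)c1)NCC1CC1` gives 312 nM in this assay, and the step of a 2.3-fold lower number from compound 2 to compound 3 (0.36 log units; beyond the scatter) is a modest gain. Compound 4 `CN(C)S(=O)(=O)CCCNc1nonc1/C(=N/O)Nc1ccc(F)c(Br)c1` carries (dimethylsulfamoyl)methyl in place of aminosulfamoyl on a saturated chain carbon, two bonds along the chain from a nitrogen on an aromatic ring. For the measured compounds named here, two measured steps bear on this. The step of a 2.3-fold lower number from compound 2 to compound 3 (0.36 log units; beyond the scatter) shows that putting an amino on the sulfonamide nitrogen went with a modest gain, and compound 4 gives that amino up for two methyls while also lengthening the chain. The step of a 1.6-fold lower number from compound 1 to compound 3 (0.20 log units; within the scatter) shows that a differently built sulfur group on that nitrogen landed within the scatter. The account therefore expects compound 4 to move back toward the number of compound 2, a modest rise in this assay, a 2.2-fold higher number from compound 3 to compound 4 (0.35 log units; beyond the scatter). Compound 4 is estimated at 300 nM, with a range from 120 nM to 750 nM.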

Compound 4, half-maximal inhibitory concentration: 97 nM
Compound 4: middle estimate off by 3.1-fold (0.49 log units), on the high side; measured number outside the range, below it.
By their numbers in this assay, from the lowest: compounds 4, 3, 1 and 2 (each within the scatter of the next, the first and the last beyond it).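

In this assay, the amino on the sulfonamide nitrogen proves not to be required at this position: (dimethylsulfamoyl)methyl, with 0 hydrogen-bond donors against 2 for aminosulfamoyl, gives the step of a 1.4-fold lower number from compound 3 to compound 4 (0.14 log units; within the scatter) even with the chain lengthened. The same group also stands apart from the (cyclopropylmethyl)sulfamoyl group in the step of a 3.2-fold lower number from compound 2 to compound 4 (0.51 log units; beyond the scatter) and from the four-membered sulfur ring in the step of a 2.2-fold lower number from compound 1 to compound 4 (0.34 log units; beyond the scatter), so a fully substituted sulfonamide nitrogen on the longer chain is at least as good as any sulfur group shown. Nothing measured here accounts for these steps.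

Compound 4 changes the nitrogen substituents and the chain length together, and the compounds shown do not separate the two. On these data alone, a 2-(dimethylsulfamoyl)ethyl group would do so, and how a carboxylic acid or an amine at the chain end would compare also stays open.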